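The compounds below may be only part of what the source reports. "The series", "measured", "known", "first", "only" and "open" are said of these compounds alone.

Compound 1 `O=C(Nc1cc(C(F)(F)F)cc(C(F)(F)F)c1)c1ccc(-c2ccccc2)cc1O` and compound 2 `N#Cc1ccc(NC(=O)c2ccc(C(F)(F)F)cc2O)cc1` share an amide built on a hydroxy-bearing core, and both were tested in a functional assay on HL-60 cells (Homo sapiens) for cytotoxicity, read by luminescence and CellTiter-Glo, with a stated time of 3 days; on this read-out higher numbers stand for weaker inhibition and lower numbers for stronger inhibition. In this assay compound 1 gives 1140 nM, and in this assay compound 2 gives 1030 nM. Compound 2 stands with its number alongside that of compound 1, the two lying within the usual scatter of such measurements, so nothing separates them on this read-out.

Compound 3 `N#Cc1ccc(NC(=O)c2ccccc2O)cc1` has not yet been measured. It differs from compound 2 in one place: hydrogen in place of trifluoromethyl on an aromatic carbon. Going by the values given here, no pair of measured compounds shows the effect of this particular change, so its size here is a matter of expectation rather than of observation. On the shown numbers, a small step from compound 2 to compound 3 toward weaker inhibition is expected, a 1.9-fold higher number from compound 2 to compound 3 (0.29 log units; within the scatter), close to the edge of the scatter rather than clearly beyond it. The estimate for compound 3 in this assay is 2000 nM, expected to fall between 800 nM and 6000 nM.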

Compound 3, half-maximal inhibitory concentration: 4620 nM
The estimate for compound 3 lay 2.3-fold (0.36 log units) below the measured number; the measured number falls inside the stated range.
By their numbers in this assay, from the lowest: compounds 2 and 1 (each within the scatter of the next); then compound 3.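

Replacing trifluoromethyl with hydrogen on this aromatic carbon, meta to a hydroxy group and para to a large group, gives in this assay a 4.5-fold higher number from compound 2 to compound 3 (0.65 log units; beyond the scatter) and so shows that this position is not indifferent to what sits on it. Going by these compounds alone, the step is modest, but it is the first reading of this position. Compound 1 differs from compound 2 in more than one place and could not show the effect of this single change. No measurement shown here explains why inhibition is stronger with trifluoromethyl on this carbon than with hydrogen.

The compounds shown leave open whether trifluoromethyl is special or whether another group on the same carbon, such as a methyl group, a chlorine atom, a methoxy group or an amine, would give a number like that of compound 2 or one further from it. Within the data shown here, also open is whether the same change would have a step of similar size in a compound with a different amide part, since this one pair is the only reading of it so far.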